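The source may report more compounds than this note shows. Statements on the series, on what has been measured and on what is new or still open speak of the compounds shown alone.

Going by the values given here, in a functional assay on HL-60 cells (Homo sapiens) for antiproliferative activity, read by MTT assay, with a stated time of 72 h (a lower number here means a stronger inhibitor, a higher number a weaker inhibitor), three compounds sharing one core have numbers so far: compound 1 `COc1cc(C(=O)c2sc3ccccc3c2-c2ccccc2)cc(OC)c1OC` gives 1700 nM, compound 2 `COc1cc(C(=O)c2sc3ccccc3c2-c2ccc(Cl)cc2)cc(OC)c1OC` gives 3300 nM, and compound 3 `COc1cc(C(=O)c2sc3ccccc3c2-c2ccc(C)cc2)cc(OC)c1OC` gives 1400 nM. Compound 3 therefore cannot be told apart from compound 1, and it stands modestly below compound 2. Compound 4 `CCOc1ccc(-c2c(C(=O)c3cc(OC)c(OC)c(OC)c3)sc3ccccc23)cc1` has ethoxy in place of methyl on an aromatic carbon, the same place that varies among the measured compounds, so 4-methylphenyl becomes 4-ethoxyphenyl: ethoxy in place of methyl on an aromatic carbon. Among the compounds with values here, no measured compound carries a group of this kind there, so the evidence is indirect. Changes at this place have been small so far. Adding a group gave a 1.2-fold lower number from compound 1 to compound 3 (0.08 log units; within the scatter) and a 1.9-fold higher number from compound 1 to compound 2 (0.29 log units; within the scatter), while swapping one group for another gave a 2.4-fold lower number from compound 2 to compound 3 (0.37 log units; beyond the scatter), the only step beyond the scatter. A similarly small move is therefore expected, with no firm direction. The estimated step is a 1.2-fold lower number from compound 3 to compound 4 (0.07 log units; within the scatter). For compound 4 the expected value is 1200 nM, with an estimated range of 400 nM to 3500 nM.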

Compound 4, half-maximal inhibitory concentration: 3500 nM
Compound 4: the middle estimate sits 2.9-fold (0.46 log units) below what was measured; measured number inside the range.
By their numbers in this assay, from the lowest: compounds 3, 1, 2 and 4 (each within the scatter of the next, the first and the last beyond it).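

In this assay, the change from 4-methylphenyl to 4-ethoxyphenyl gives a 2.5-fold higher number from compound 3 to compound 4 (0.40 log units; beyond the scatter), and putting ethoxy in place of the hydrogen of the unsubstituted phenyl gives a 2.1-fold higher number from compound 1 to compound 4 (0.31 log units; beyond the scatter), so an oxygen-linked group at this place moves the number beyond the scatter in the weaker direction. Ethoxy and chloro, however, cannot be told apart here, with a 1.1-fold higher number from compound 2 to compound 4 (0.03 log units; within the scatter), even though the two groups differ in atoms and in hydrogen-bond acceptors. Nothing measured on these compounds explains the shifts at this position.

The compounds shown leave open whether the shorter methoxy or a longer chain such as butoxy would follow ethoxy. They also leave open how an amine or a carboxylic acid at this place would read in this assay.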